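A few compounds are considered here, and "the series" means these few. Any claim that something is new, unique, unknown or untested is made for them only; others in the source may bear on it.

Compound 1 `COC(=O)CN1C(=O)c2ccccc2NC1c1ccco1` and compound 2 `COC(=O)CN1C(=O)c2ccccc2NC1c1ccc(OC)cc1` share one core and differ only by 4-methoxyphenyl in place of furan-2-yl on a saturated ring carbon. In an assay on mitochondria for inhibition of Amine oxidase [flavin-containing] B (Bos taurus), read by fluorescence, with a stated time of 60 min (a lower number here means a stronger inhibitor, a higher number a weaker inhibitor), compound 1 gives 380000 nM, while compound 2 gives 560000 nM, which amounts to a 1.5-fold higher number from compound 1 to compound 2 (0.17 log units; within the scatter). Compound 1 thus sits at the low end of the two numbers, with compound 2 its only neighbor and within the scatter of it. Compound 3 `COC(=O)C(C)N1C(=O)c2ccccc2NC1c1ccco1` keeps the furan-2-yl group of compound 1 and differs from it by methyl in place of hydrogen on a saturated chain carbon bound to an amide-type nitrogen in a ring and a carbonyl carbon. For the measured compounds named here, no measured step touches this place: the single known step, from compound 1 to compound 2, altered the group on the saturated ring carbon and left the numbers within the scatter. For compound 3 the expectation is therefore no step beyond the scatter in this assay, estimated as no change at the digits printed from compound 1 to compound 3 (within the scatter). Compound 3 is estimated at 380000 nM, expected to lie between 150000 nM and 1000000 nM.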

Compound 3, half-maximal inhibitory concentration: 61000 nM
Estimate against measurement, compound 3: 6.2-fold (0.79 log units) above, and the stated range ends above it.
By their numbers in this assay, from the lowest: compound 3; then compounds 1 and 2 (each within the scatter of the next).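

For the compounds shown here, the saturated chain carbon bound to an amide-type nitrogen in a ring and a carbonyl carbon is a place where this assay responds: methyl in place of hydrogen there gives a 6.2-fold lower number from compound 1 to compound 3 (0.79 log units; beyond the scatter) while the only earlier change, on the saturated ring carbon, gave a 1.5-fold higher number from compound 1 to compound 2 (0.17 log units; within the scatter) and stayed within the scatter. Going by these compounds alone, the shared core therefore shows a step beyond the scatter for the first time, from the change of (methoxycarbonyl)methyl to 1-(methoxycarbonyl)ethyl. No measurement at hand offers a cause for this step.

The compounds shown leave open whether an ethyl group or a longer chain on this carbon would move the number further, or whether a carboxylic acid in place of the methyl ester would keep the step. They also leave open whether the same methyl step would appear with 4-methoxyphenyl on the saturated ring carbon.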